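Swapping one side group: from compound 2 to compound 4

The source may report more compounds than this note shows. Statements on the series, on what has been measured and on what is new or still open speak of the compounds shown alone.

Measured so far in a physicochemical assay for lipophilicity, at pH 7.4 (a lower number here means a more polar compound, a higher number a more lipophilic compound), are three compounds
Compound 1 `CC(C)CN(c1ccc(C#N)cc1)S(=O)(=O)c1ccc2c(c1)C(=O)CC(C1CCOCC1)O2` gives 3.16
Compound 2 `CCc1ccc(N(CC(C)C)S(=O)(=O)c2ccc3c(c2)C(=O)CC(CC2CCOCC2)O3)cc1` gives 4.53
Compound 3 `CCc1ccc(N(CC(C)C)S(=O)(=O)c2ccc3c(c2)C(=O)N(C2CCOCC2)C3)cc1` gives 3.64

Compound 2 stands highest of the three. Compound 3 lies nearest to it and compound 1 furthest, both gaps beyond the usual scatter. Compound 4 `CCc1ccc(N(CC(C)C)S(=O)(=O)c2ccc3c(c2)C(=O)CC(C2CCN(S(C)(=O)=O)CC2)O3)cc1` is still unmeasured. It carries 1-(methylsulfonyl)piperidin-4-yl in place of (oxan-4-yl)methyl on a saturated ring carbon. Within the data shown here, no measured pair isolates this change, so any expectation is loose. A moderate fall beyond the scatter is expected, estimated as a number 0.63 log units lower from compound 2 to compound 4 (beyond the scatter) in this assay here. Compound 4 is expected at 3.9 (estimated range 3.4 to 4.4).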

Compound 4, distribution coefficient: 3.31
Compound 4: middle estimate off by 0.59 log units, on the high side, outside the stated range (below it).
By their numbers in this assay, from the lowest: compounds 1 and 4 (each within the scatter of the next); then compound 3; then compound 2.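

In this assay, putting 1-(methylsulfonyl)piperidin-4-yl in place of (oxan-4-yl)methyl on the saturated ring carbon next to the ring oxygen gives a number 1.22 log units lower from compound 2 to compound 4 (beyond the scatter), a large step. This is the first change in a single place among these compounds, and it shows that this position can shift the number strongly. Nothing available explains the size of this step.

Going by these compounds, how much of the step belongs to the methylsulfonyl group, and how much to the ring carrying it, remains open. A piperidin-4-yl bearing an acetyl group at this carbon would help separate the two.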